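Inverting the ring stereochemistry of a fluoro indole amine

The compounds below may be only part of what the source reports. "The series", "measured", "known", "first", "only" and "open" are said of these compounds alone.

Compound 2, `Fc1ccc2[nH]cc([C@H]3CC[C@@H](NCc4ccccc4)CC3)c2c1`, was examined in an assay on cell membranes for binding affinity to Adrenergic receptor alpha-1 (Rattus norvegicus), tested at 1 uM (a higher number here means more inhibition at the concentration tested (going by the name of the read-out), a lower number less inhibition), and gives 9%. That is the lowest of the two numbers recorded: compound 1, `N#Cc1ccc2[nH]cc([C@H]3CC[C@H](NCc4ccccc4)CC3)c2c1`, gives 28% in this assay, a figure higher than that of compound 2 by a margin beyond the usual scatter. Compound 3, `Fc1ccc2[nH]cc([C@H]3CC[C@H](NCc4ccccc4)CC3)c2c1`, is not yet measured. It differs from compound 2 as follows: the two compounds have the same atoms and bonds and differ only in configuration as drawn: 2 of 2 stereo elements differ (all stereocentres are inverted: mirror images); a stereocentre at a saturated ring carbon is drawn s in compound 2 and r in compound 3; a stereocentre at a saturated ring carbon is drawn s in compound 2 and r in compound 3. Going by the values given here, no step between two measured compounds isolates this kind of change, so its effect cannot be read from the data; compound 1, which shares the drawn configuration of compound 3 but carries a nitrile in place of fluorine, offers only indirect guidance. A modest increase from compound 2 to compound 3 is expected, of about a number 11 percentage points higher from compound 2 to compound 3 (beyond the scatter), not far beyond the scatter. Compound 3 is therefore estimated to give 20% in this assay, within a range from 5% to 40%.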

Compound 3, a percentage reported as inhibition, at one concentration (the size of the read-out at that concentration, not a potency): 8%
Compound 3: the middle estimate sits 12 percentage points above what was measured; measured number inside the range.
By their numbers in this assay, from the lowest: compounds 3 and 2 (each within the scatter of the next); then compound 1.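

In this assay the step of a number 1 percentage points lower from compound 2 to compound 3 (within the scatter) shows that, with the fluoro indole amine, inverting both ring stereocentres makes no difference that can be told from the scatter. Going by these compounds alone, this pair isolates configuration alone, which the earlier compounds could not do: the fact that compounds 2 and 3 differ only in the configuration as drawn. With the drawn configuration held the same, the aromatic substituent does separate the compounds, since the step of a number 20 percentage points lower from compound 1 to compound 3 (beyond the scatter) comes with fluoro in place of cyano on an aromatic carbon and lies beyond the scatter.

Whether configuration matters as little when a nitrile sits on that aromatic carbon remains open, as the mirror image of compound 1 is not among the compounds shown. Also open, going by these compounds, is how a chlorine atom or a methoxy group on that carbon would compare with fluoro and cyano.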